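Iodine on a Ring Carbon in a Weak Cell Growth Series

The source may report more compounds than this note shows. Statements on the series, on what has been measured and on what is new or still open speak of the compounds shown alone.

Of the compounds shown here, three have been measured in a functional assay on NCI/ADR cells (Homo sapiens) for inhibition, read by sulforhodamine B assay, with a stated time of 48 h; on this read-out lower numbers stand for stronger inhibition of growth and higher numbers for weaker inhibition of growth. Compound 1 `O=c1ccoc(/C=C/c2ccccc2)c1` gives 514 uM. Compound 2 `COc1ccc(C2CC(=O)C=CO2)cc1` gives 420 uM; this is the lower of the two numbers, and the gap to compound 1 lies within the scatter, so the two cannot be told apart. Compound 3 `COc1ccc(-c2cc(=O)cco2)cc1` gives only a limit of the assay, > 1230 uM, with the limit of > 1230 uM in this assay, at which 1 of the 3 values shown sits.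

Compound 4 `COc1ccc(C2CC(=O)C(I)=CO2)cc1` is not yet measured. It differs from compound 2 by iodo in place of hydrogen on a double-bonded ring carbon. Among the compounds with values here, no measured pair shows the effect of such a change here, so the expected step is a modest one toward stronger growth inhibition, a 1.7-fold lower number from compound 2 to compound 4 (0.23 log units; within the scatter), not far beyond the scatter. In this assay compound 4 is therefore estimated at 250 uM, likely between 80 uM and 800 uM.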

Compound 4, concentration for growth inhibition (reported as GI): 39.7 uM
Beside the measured number, compound 4's estimate is 6.3-fold (0.80 log units) above it; the measured number lies below the stated range.
By their numbers in this assay, from the lowest: compound 4; then compounds 2 and 1 (each within the scatter of the next). At a limit, above all of these: compound 3.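

In this assay, iodo in place of hydrogen on a double-bonded ring carbon gives an 11-fold lower number from compound 2 to compound 4 (1.02 log units; beyond the scatter), the only step shown so far and a large one. This ring carbon, two ring bonds from the ring oxygen, is therefore a place where one added atom can change growth inhibition strongly. Nothing at hand explains why the step is this large.

On these data alone, whether iodine itself is needed stays open, as no value here speaks for bromo, a methyl group or an amine on this carbon. As far as these compounds go, whether iodo has the same effect on the core of compound 1 is also open.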